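This account rests on a few compounds, and the source may have more. Where it says the series, first, only, none or still open, it means among the compounds named here.

In an ADME assay on Vero 76 cells (Chlorocebus sabaeus) for cytotoxicity, read by MTT assay, with a stated time of 96 h (a lower number here means that less compound is tolerated, a higher number that more compound is tolerated), compound 1 (`FC(F)(F)c1ccc(-c2nn(-c3ccccc3)cc2CNc2ccc(Cl)cc2)cc1`) gives 10000 nM, compound 2 (`Brc1ccc(NCc2cn(-c3ccccc3)nc2-c2ccccc2)cc1`) gives 52000 nM and compound 3 (`Brc1ccc(NCc2cn(-c3ccccc3)nc2-c2ccc(Br)cc2)cc1`) gives 88000 nM. Compound 3 therefore lies within the scatter of compound 2 and beyond the scatter above compound 1.

The next step leads to compound 4 (`FC(F)(F)c1ccc(-c2nn(-c3ccccc3)cc2CNc2ccc(Br)cc2)cc1`): trifluoromethyl in place of bromo on an aromatic carbon. This is trifluoromethyl in place of bromo on an aromatic carbon, para to a large group, or 4-bromophenyl to 4-(trifluoromethyl)phenyl.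

For the measured compounds named here, only one measured step bears on this place: a 1.7-fold higher number from compound 2 to compound 3 (0.23 log units; within the scatter), with bromo in place of hydrogen on an aromatic carbon. That step stays within the scatter, but it says nothing directly about trifluoromethyl. Going by the values given here, the only measured compound with the 4-(trifluoromethyl)phenyl group is compound 1, at 10000 nM, and a single compound makes no trend. Its value still points towards a lower number in this assay, so a moderate drop beyond the scatter is the working expectation, with real uncertainty.

The expected change is an estimated 3.5-fold lower number from compound 3 to compound 4 (0.55 log units; beyond the scatter). Compound 4 is estimated at 25000 nM, with an expected range of 9000 nM to 60000 nM.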

Compound 4, half-maximal cytotoxic concentration: 17000 nM
For compound 4 the middle estimate is 1.5-fold (0.17 log units) above the measured one; the range from low to high includes it.
By their numbers in this assay, from the lowest: compounds 1 and 4 (each within the scatter of the next); then compounds 2 and 3 (each within the scatter of the next).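

In this assay, the change from 4-bromophenyl to 4-(trifluoromethyl)phenyl gives a 5.2-fold lower number from compound 3 to compound 4 (0.71 log units; beyond the scatter) and is a step beyond the scatter at a place where the earlier step, a 1.7-fold higher number from compound 2 to compound 3 (0.23 log units; within the scatter) for bromo in place of hydrogen, stayed within it. Trifluoromethyl in place of hydrogen at the same place gives a 3.1-fold lower number from compound 2 to compound 4 (0.49 log units; beyond the scatter) and also lies beyond the scatter, so on these three compounds trifluoromethyl is separated from both hydrogen and bromo, while hydrogen and bromo are not separated from each other. Elsewhere in the molecule, bromo in place of chloro gives a 1.7-fold higher number from compound 1 to compound 4 (0.23 log units; within the scatter) and stays within the scatter, so the two trifluoromethyl compounds sit together whichever of these two halogens they carry.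

Going by these compounds, how a carboxylic acid, an amine or a methoxy group at this place would read remains open, so it cannot be said whether trifluoromethyl stands alone here or is one case of a wider trend. On these data alone, it is also open whether the same step would appear with the chloro compound's partners, since only compound 1 carries chloro. Nothing on hand gives a reason for these steps.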